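The source may report more compounds than this note shows. Statements on the series, on what has been measured and on what is new or still open speak of the compounds shown alone.

Of the compounds shown here, three built on one shared core have been read in a functional assay on PC-3 cells (Homo sapiens) for inhibition, read by sulforhodamine B assay, with a stated time of 48 h, tested at 50 uM; on this read-out lower numbers stand for less inhibition of growth and higher numbers for more inhibition of growth at the one concentration tested: compound 1 `COc1ccc2c(c1)C(=O)C(=O)N2CCCn1cc(COc2cc(=O)oc3ccccc23)nn1` gives 9%, compound 2 `O=C1C(=O)N(CCCn2cc(COc3cc(=O)oc4ccccc34)nn2)c2ccc(I)cc21` gives 14%, and compound 3 `O=C1C(=O)N(CCCn2cc(COc3cc(=O)oc4ccccc34)nn2)c2ccc(F)cc21` gives 20%. Among the compounds with values here, the numbers place compound 3 clear of only one neighbour. They show a number 11 percentage points higher from compound 1 to compound 3 (beyond the scatter), but also a number 6 percentage points higher from compound 2 to compound 3 (within the scatter).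

Compound 4 `O=C1C(=O)N(CCCn2cc(COc3cc(=O)oc4ccccc34)nn2)c2ccc(Cl)cc21` alters compound 3 at a single site: chloro in place of fluoro on an aromatic carbon. Within the data shown here, no measured pair makes this exact exchange. The closest evidence is the swap between two other halogens, which gave a number 6 percentage points higher from compound 2 to compound 3 (within the scatter). The iodo-for-methoxy swap gave a number 5 percentage points higher from compound 1 to compound 2 (within the scatter), so it also stays small, while the larger a number 11 percentage points higher from compound 1 to compound 3 (beyond the scatter) starts from methoxy rather than a halogen and bears less directly. No step beyond the scatter is therefore expected in this assay. The expected change is a number 3 percentage points lower from compound 3 to compound 4 (within the scatter). For compound 4 the estimated value is 17%, with an expected range from 7% to 28%.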

Compound 4, percent growth inhibition at one concentration: 18%
For compound 4 the middle estimate is 1 percentage points below the measured one; low and high end bracket the measured number.
By their numbers in this assay, from the lowest: compounds 1, 2, 4 and 3 (each within the scatter of the next, the first and the last beyond it).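

In this assay, within the data shown here, the chloro group gives a third halogen on this aromatic carbon, and exchanging fluoro for it gives (a number 2 percentage points lower from compound 3 to compound 4 (within the scatter)), while exchanging iodo for it gives (a number 4 percentage points higher from compound 2 to compound 4 (within the scatter)), so no pair among the three halogens is separated beyond the scatter. Among these compounds, the step from methoxy to chloro (a number 9 percentage points higher from compound 1 to compound 4 (within the scatter)) also stays within the scatter, which leaves the step from methoxy to fluoro (a number 11 percentage points higher from compound 1 to compound 3 (beyond the scatter)) as the only one of these exchanges that exceeds it. No measurement available here explains these small differences.

The compounds shown leave open how this position responds to a group that is neither a halogen nor methoxy, such as an amine or a carboxylic acid. They also leave open whether a longer chain on this aromatic carbon would give a step beyond the scatter from compound 3 or compound 4.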